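Working notes on compound 1, compound 2 and compound 3

The source may hold more compounds than are shown below. What is called first, only, known or untested is meant among the compounds shown, and "the series" means these compounds.

Compound 1 `O=C1Nc2ccc(S(=O)(=O)N3CCOCC3)cc2/C1=N/NS(=O)(=O)c1ccccc1` gives 25300 nM in a functional assay on MCF7 cells (Homo sapiens) for cytotoxicity, read by sulforhodamine B assay, with a stated time of 24 h; a higher number here means a weaker inhibitor, a lower number a stronger inhibitor. Among the compounds with values here, this is the lowest of the two numbers measured so far, but compound 2 `COc1ccc(-c2c(C#N)c(N)n(/N=C3\C(=O)Nc4ccc(S(=O)(=O)N5CCOCC5)cc43)c(=O)c2C#N)cc1` gives 33400 nM in this assay, and the two values lie within the scatter of each other, so no ordering is drawn between them.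

Compound 3 `O=C1Nc2ccc(S(=O)(=O)N3CCOCC3)cc2/C1=N/c1ccc(Br)cc1` has not yet been measured. Relative to compound 1 it shows (4-bromophenyl in place of (phenylsulfonyl)amino on a double-bonded nitrogen). Within the data shown here, no measured pair in the set differs in this way, so the size of such a step is unknown from the data; with only two values, both in the same weak range, nothing supports a move beyond the scatter in either direction. The step of a 1.2-fold lower number from compound 1 to compound 3 (0.06 log units; within the scatter) is therefore expected to stay within the scatter. The estimate for compound 3 in this assay is 22000 nM, with a range from 7000 nM to 70000 nM.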

Compound 3, half-maximal inhibitory concentration: 44800 nM
Compound 3: middle estimate off by 2.0-fold (0.31 log units), on the low side, and the stated range covers the measured number.
By their numbers in this assay, from the lowest: compounds 1, 2 and 3 (each within the scatter of the next).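

In this assay, within the data shown here, the step of a 1.8-fold higher number from compound 1 to compound 3 (0.25 log units; within the scatter) comes with 4-bromophenyl in place of (phenylsulfonyl)amino on a double-bonded nitrogen, the first measured change at this place. The swap removes the hydrogen-bond donor and acceptors of the leaving group, and a replacement with no hydrogen-bond donors or acceptors still stays within the scatter, so these counts do not separate compound 1 and compound 3 in this assay. No measurement bearing on either group is available to account for this result.

From the compounds shown here alone, whether an amine or a carboxylic acid on this nitrogen would move the number beyond the scatter remains open. The compounds shown also leave open whether a simple phenyl or a longer chain here would give a step of any greater size.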